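The source may report more compounds than this note shows. Statements on the series, on what has been measured and on what is new or still open speak of the compounds shown alone.

Compound 1 `O=C(Nc1cccc(-n2cc(-c3ccncc3)c(-c3ccc(Cl)c(O)c3)n2)c1)Nc1ccc(Cl)c(Cl)c1` and compound 3 `O=C(Nc1cccc(-n2cc(-c3ccncc3)c(-c3ccc(Cl)c(O)c3)n2)c1)Nc1cc(C(F)(F)F)cc(C(F)(F)F)c1` share a core that carries a urea, and in a functional assay on OVCAR-5 cells (Homo sapiens) for inhibition, read by sulforhodamine B assay, with a stated time of 48 h (on this read-out lower numbers stand for stronger inhibition of growth and higher numbers for weaker inhibition of growth), compound 1 gives 2400 nM, while compound 3 gives 875 nM. Compound 2 `COc1cc(-c2nn(-c3cccc(NC(=O)c4ccc(Cl)c(C(F)(F)F)c4)c3)cc2-c2ccncc2)ccc1Cl` differs from both in that its core bears a methoxy group and the attachment to the aryl ring is an amide rather than a urea. In this assay compound 2 reaches only the limit of the measurement, > 32500 nM, so no number is known for it; this is the limit of > 32500 nM in this assay, at which 1 of the 3 values shown sits, and compound 2 is the only one of the three at that limit.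

Compound 4 `COc1cc(-c2nn(-c3cccc(NC(=O)Nc4ccc(Cl)c(C(F)(F)F)c4)c3)cc2-c2ccncc2)ccc1Cl` has not yet been measured. It differs from compound 2 in a single place: (4-chloro-3-(trifluoromethyl)phenyl)amino in place of 4-chloro-3-(trifluoromethyl)phenyl on a carbonyl carbon. The two measured ureas, compound 1 and compound 3, both return numbers well inside the range of this assay, whereas the amide compound 2 does not. On that basis compound 4 is expected to move an at least 6.5-fold lower number from compound 2 to compound 4 (0.81 log units; beyond the scatter), into the numbered range, and its estimated value in this assay is 5000 nM, within 1500 nM to 32500 nM.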

Compound 4, concentration for 50% growth inhibition: 3090 nM
Compound 4: middle estimate off by 1.6-fold (0.21 log units), on the high side, and the stated range covers the measured number.
By their numbers in this assay, from the lowest: compound 3; then compounds 1 and 4 (each within the scatter of the next). At a limit, above all of these: compound 2.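

In this assay, among these compounds, the carbonyl carbon gives the first comparison in which only one place differs: (4-chloro-3-(trifluoromethyl)phenyl)amino in place of 4-chloro-3-(trifluoromethyl)phenyl gives an at least 10-fold lower number from compound 2 to compound 4 (1.02 log units; beyond the scatter). Compounds 1 and 3 differ from compound 2 in more than one place, whereas this pair ties the move from amide to urea to the change in number with the methoxy-bearing core held constant. From the compounds shown here alone, the true size of the step remains unknown, because compound 2 stands at a limit: the limit of > 32500 nM in this assay, at which 1 of the 4 values shown sits.

The compounds shown leave open whether another link on the carbonyl carbon, such as the oxygen of a carbamate or a methylene group, would serve as the urea nitrogen does. They also leave open how compound 4 would respond if its methoxy group were replaced by the hydroxyl group carried by compounds 1 and 3.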